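Methoxy Additions on a Fluorinated Stilbene Core

The compounds below may be only part of what the source reports. "The series", "measured", "known", "first", "only" and "open" are said of these compounds alone.

Compound 1 `Fc1ccccc1/C=C/c1ccccc1` is the starting point of this small set. In an assay on HepG2 cells for activation of nuclear factor erythroid 2-related factor 2 (Homo sapiens), read by a luciferase reporter, with a stated time of 5 h (a higher number here means that more compound is needed for the effect, a lower number that less compound is needed), compound 1 gives 700 nM. Compound 2 `Fc1cccc(/C=C/c2ccccc2)c1` is built from the same atoms as compound 1, joined differently; the difference between the two cores is not broken down here. In this assay compound 2 gives 3100 nM. Compound 3 `COc1ccccc1/C=C/c1ccccc1F` carries, relative to compound 1, (methoxy in place of hydrogen on an aromatic carbon); in this assay compound 3 gives 3100 nM, and a 4.4-fold higher number from compound 1 to compound 3 (0.65 log units; beyond the scatter). Compound 2 and compound 3 stand level at the digits shown, within the usual scatter of each other.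

Compound 4 `COc1cccc(/C=C/c2cccc(F)c2)c1` has not yet been measured. It differs from compound 2 by methoxy in place of hydrogen on an aromatic carbon. This is the same kind of change as that from compound 1 to compound 3, but the place differs: in compound 3 the methoxy sits ortho to a group of 9 heavy atoms, in compound 4 meta to a group of 9 heavy atoms. For the measured compounds named here, because a 4.4-fold higher number from compound 1 to compound 3 (0.65 log units; beyond the scatter) raised the number in the one measured example of this change, compound 4 is expected to show a 2.6-fold higher number from compound 2 to compound 4 (0.41 log units; beyond the scatter), a step in the same direction, held with caution since the place is not the same. The estimate for compound 4 in this assay is 8000 nM, between 3000 nM and 25000 nM.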

Compound 4, half-maximal effective concentration: 2300 nM
Beside the measured number, compound 4's estimate is 3.5-fold (0.54 log units) above it; measured number below the stated range.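

In this assay methoxy in place of hydrogen on an aromatic carbon gives a 1.3-fold lower number from compound 2 to compound 4 (0.13 log units; within the scatter) and so, on this core, a step too small to tell apart from repeat measurements. Set beside the earlier example, the same change did not carry over unchanged from one core to the other: the same change on two cores in this assay, a 4.4-fold higher number (0.65 log units; beyond the scatter) from compound 1 to compound 3 and a 1.3-fold lower number (0.13 log units; within the scatter) from compound 2 to compound 4, 6.0-fold (0.78 log units) apart, beyond the scatter of two such steps. This does not show why the two steps part, since the two pairs differ both in the core and in where the methoxy sits, and two examples are too few to support a rule for the series.

The compounds shown leave open whether the gap follows the core or the place of the methoxy, a question that would need the same place compared on both cores. Also open, on these data alone, is how a different group, such as an amine or a carboxylic acid, would behave in place of that hydrogen on either core.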